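Replacing thiophen-2-yl with 4-cyanophenyl

The source may hold more compounds than are shown below. What is called first, only, known or untested is meant among the compounds shown, and "the series" means these compounds.

Values in a functional assay on NB-4 cells (Homo sapiens) for cytotoxicity, read by CCK-8 assay, with a stated time of 24 h; on this read-out lower numbers stand for stronger inhibition and higher numbers for weaker inhibition:
compound 1 `C=CC(=O)N1C(=O)CC(c2ccc(Br)cc2)Sc2ccccc21`: 59400 nM
compound 2 `C=CC(=O)N1C(=O)CC(c2cccs2)Sc2ccccc21`: 765000 nM
compound 3 `C=CC(=O)N1C(=O)CC(c2ccccc2C(F)(F)F)Sc2ccccc21`: 35200 nM

Of these three, compound 2 has the highest number, 765000 nM, and its gaps to both others lie beyond the scatter. Compound 4 `C=CC(=O)N1C(=O)CC(c2ccc(C#N)cc2)Sc2ccccc21` has not yet been measured. It differs from compound 2 by 4-cyanophenyl in place of thiophen-2-yl on a saturated ring carbon, with 4-cyanophenyl in place of thiophen-2-yl on a saturated ring carbon.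

Among the measured compounds shown here, one measured step bears directly on this change: a 13-fold higher number from compound 1 to compound 2 (1.11 log units; beyond the scatter), a large step in which thiophen-2-yl replaces 4-bromophenyl at that same place. Compound 4 reverses that kind of change, since it also swaps between thiophen-2-yl and a substituted phenyl group. For the measured compounds named here, a large step of similar size towards a lower number is therefore expected in this assay, although no nitrile-bearing compound has been measured. The expected change is a 13-fold lower number from compound 2 to compound 4 (1.11 log units; beyond the scatter). For compound 4 the estimated value is 60000 nM, with an expected range of 20000 nM to 200000 nM.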

Compound 4, half-maximal inhibitory concentration: 62400 nM
Estimate against measurement, compound 4: 1.0-fold (0.02 log units) below; measured number inside the range.
By their numbers in this assay, from the lowest: compounds 3, 1 and 4 (each within the scatter of the next); then compound 2.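

In this assay the change from thiophen-2-yl to 4-cyanophenyl on the saturated ring carbon gives a 12-fold lower number from compound 2 to compound 4 (1.09 log units; beyond the scatter) and so shows that the earlier gap is not tied to 4-bromophenyl alone. Cyano in place of bromo on the aromatic carbon gives a 1.1-fold higher number from compound 1 to compound 4 (0.02 log units; within the scatter) and so separates these two groups by nothing beyond the scatter in this assay. No measured evidence at hand accounts for either step.

As far as these compounds go, it remains open whether a plain phenyl group, or a phenyl group carrying an amine or a carboxylic acid, would stay with compound 1 and compound 4 or move towards compound 2. Also open, from the compounds shown here alone, is what the vinylcarbonyl group, shared by all four compounds, contributes, for instance compared with a propanoyl group.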